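Working notes: from compound 1 to compound 3

This account rests on a few compounds, and the source may have more. Where it says the series, first, only, none or still open, it means among the compounds named here.

In an ADME assay for pharmacokinetics (a higher number here means that the compound lasts longer, a lower number that the compound disappears faster), compound 1 `C[C@@H](NC(=O)Nc1ccc2c(Cl)c(OCCSC(=N)N)oc(=O)c2c1)c1ccccc1` gives 1.03 h. Among the measured compounds shown here, the only other measured compound, compound 2 `N=C(N)SCCCOc1oc(=O)c2cc(N)ccc2c1Cl`, gives 1.5 h. For the measured compounds named here, these two values lie within the usual scatter of each other, so they set no order, and compound 1 stands level with the only comparison available.

Compound 3 `CC(=O)CCC(=O)Nc1ccc2c(Cl)c(OCCSC(=N)N)oc(=O)c2c1` keeps the core of compound 1 and changes one group: 2-acetylethyl in place of (1-phenylethyl)amino on a carbonyl carbon. In words, this is 2-acetylethyl in place of (1-phenylethyl)amino on a carbonyl carbon, and the amide-type nitrogen stays in place.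

Going by the values given here, no step between measured compounds that differ in one place is available, so the size of this change cannot be read from the data. Among the compounds with values here, the only guide is the close agreement of the measured pair, with compound 1 at 1.03 h and compound 2 at 1.5 h. The expected change in this assay is therefore small, with no shift beyond the scatter in either direction: the estimate is a 1.2-fold higher number from compound 1 to compound 3 (0.07 log units; within the scatter).

For compound 3 the estimated value is 1.2 h, with an expected range from 0.6 h to 2.4 h.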

Compound 3, half-life: 0.467 h
Estimate against measurement, compound 3: 2.6-fold (0.41 log units) above, and the stated range ends above it.
By their numbers in this assay, from the lowest: compound 3; then compounds 1 and 2 (each within the scatter of the next).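

Among the compounds shown here, this is the first step that changes one place alone, and it shows that the group on the carbonyl carbon can move the number in this assay, with a 2.2-fold lower number from compound 1 to compound 3 (0.34 log units; beyond the scatter). For the compounds shown here, the step is modest and rests on a single pair, but it is the first difference beyond the scatter: 2-acetylethyl in place of (1-phenylethyl)amino is enough to place compound 3 lowest in the order, whereas compound 1 and compound 2 set no order. The change removes the six-membered aromatic ring, the hydrogen-bond donor and the defined stereocentre of the leaving group all at once, and nothing measured here bears on the reason for the shift or on which of these differences carries it.

Going by these compounds, it remains open whether a dimethylamino group or a benzylamino group on the same carbonyl carbon would stand with compound 1 or with compound 3. On these data alone, it is equally open whether a carboxylic acid at the end of the 2-acetylethyl group, or a longer chain in its place, would change the number in this assay.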